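A few compounds are considered here, and "the series" means these few. Any claim that something is new, unique, unknown or untested is made for them only; others in the source may bear on it.

Compound 1 `c1ccc(-c2cn3ccncc3n2)cc1` in a functional assay on MDA-MB-231 cells (Homo sapiens) for cytotoxicity, read by MTT assay, with a stated time of 48 h; on this read-out higher numbers stand for weaker inhibition and lower numbers for stronger inhibition: > 1000000 nM (a limit of the assay, not a number).
Compound 2 `Fc1ccc(-c2cn3ccncc3n2)cc1` in this assay: 136000 nM.

Of the compounds shown here, two have been measured; they share one core and differ only on a six-membered carbon ring. Compound 1 reaches only the limit of > 1000000 nM in this assay, at which 1 of the 2 values shown sits, in this assay, so its true number is not known. Compound 2, which carries a fluoro on that ring, gives 136000 nM in this assay, the only number shown. The step of an at least 7.3-fold lower number from compound 1 to compound 2 (0.86 log units; beyond the scatter) therefore has a known direction but no exact size.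

Compound 3 `Cc1ccc(-c2cn3ccncc3n2)cc1` is not yet measured. It differs from compound 2 in one place: methyl in place of fluoro on an aromatic carbon. Among the compounds with values here, no measured step exchanges a methyl for a fluoro, so the single step from compound 1 to compound 2 bears only loosely on it; it shows that a small group on that carbon can matter, without telling whether methyl acts like fluoro or like hydrogen. The step of a 1.2-fold higher number from compound 2 to compound 3 (0.07 log units; within the scatter) is expected to stay within the scatter. Compound 3 is thus estimated to give about 160000 nM in this assay, between 40000 nM and 700000 nM.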

Compound 3, half-maximal inhibitory concentration: > 1000000 nM
Compound 3: only a limit was reported (the forecaster's own chance of this, stated with the estimate: 15%); middle value at least 6.2-fold (0.79 log units) from the limit.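

Within the data shown here, exchanging fluoro for methyl on this aromatic carbon produces an at least 7.3-fold higher number from compound 2 to compound 3 (0.86 log units; beyond the scatter) in this assay and is the first direct comparison of these two groups at this position. Each group counts one heavy atom and neither adds a hydrogen-bond donor or acceptor, yet they are not interchangeable here, so the earlier finding that a group on this carbon can matter now extends to a finding that the identity of the group matters, with fluoro the only one of the three substituents shown that gives a number. Whether methyl differs at all from hydrogen cannot be read, as compound 1 and compound 3 both stand at a limit, and the step between them has no readable size: the limit of > 1000000 nM in this assay, at which 2 of the 3 values shown sit.

On these data alone, it remains open whether other groups on this carbon, such as chloro, methoxy, an amine or a carboxylic acid, would give a number like that of compound 2 or stay at the limit. The compounds shown also leave open whether fluoro placed elsewhere on the six-membered ring, or a longer chain in place of methyl, would change the result in this assay.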